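A few compounds are considered here, and "the series" means these few. Any claim that something is new, unique, unknown or untested is made for them only; others in the source may bear on it.

Measured in a functional assay on CCRF-CEM cells (Homo sapiens) for inhibition, read by MTT assay, with a stated time of 72 h; a higher number here means a weaker inhibitor, a lower number a stronger inhibitor:
Compound 1 `COc1cc(NC(C)CCCNC(=O)NNC(=O)Nc2ccc(Br)cc2)c2ncccc2c1`: 110000 nM
Compound 2 `COc1cc(NC(C)CCCNC(=O)Nc2cccc(O)c2)c2ncccc2c1`: 32000 nM
Compound 3 `COc1cc(NC(C)CCCNC(=O)Nc2ccc(C(F)(F)F)cc2)c2ncccc2c1`: 14000 nM

Compound 3 has the lowest number of the three and is therefore the strongest inhibitor in this small set. Its lead is modest, though beyond the scatter: the data show a 2.3-fold lower number from compound 2 to compound 3 (0.36 log units; beyond the scatter) and a 7.9-fold lower number from compound 1 to compound 3 (0.90 log units; beyond the scatter).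

The next compound, compound 4 `COc1cc(NC(C)CCCNC(=O)NNC(=O)Nc2cccc(Cl)c2)c2ncccc2c1`, has not been measured yet. Relative to compound 3, it carries ((3-chlorophenyl)carbamoyl)amino in place of 4-(trifluoromethyl)phenyl on an amide-type nitrogen.

The closest guide is compound 1, which has ((4-bromophenyl)carbamoyl)amino at that same place and gives 110000 nM. Two measured steps start from compound 1 and replace this group with a plain substituted phenyl: a 7.9-fold lower number from compound 1 to compound 3 (0.90 log units; beyond the scatter) and a 3.4-fold lower number from compound 1 to compound 2 (0.54 log units; beyond the scatter). Both lowered the number, so putting such a group back should raise it. Among the measured compounds shown here, no measured compound shows how the 3-chloro ring compares with the 4-bromo ring, which leaves real uncertainty.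

The step expected in this assay is therefore a 5.0-fold higher number from compound 3 to compound 4 (0.70 log units; beyond the scatter), which would mean a weaker inhibitor. Compound 4 is estimated at about 70000 nM, with an expected range from 25000 nM to 160000 nM.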

Compound 4, half-maximal inhibitory concentration: 81000 nM
The estimate for compound 4 lay 1.2-fold (0.06 log units) below the measured number; measured number inside the range.
By their numbers in this assay, from the lowest: compound 3; then compound 2; then compounds 4 and 1 (each within the scatter of the next).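

In this assay, compound 4 shows that the high number of compound 1 was not a quirk of one ring, since a second compound carrying a ((aryl)carbamoyl)amino group on the amide-type nitrogen also sits well above the two plain phenyl compounds (a 5.8-fold higher number from compound 3 to compound 4 (0.76 log units; beyond the scatter); a 2.5-fold higher number from compound 2 to compound 4 (0.40 log units; beyond the scatter)). Among these four compounds, the choice between the longer group and a directly attached substituted phenyl therefore counts for more than the substituent on the ring, and no compound here goes against this. Swapping 4-bromophenyl for 3-chlorophenyl within the longer group gives no difference that can be told apart (a 1.4-fold lower number from compound 1 to compound 4 (0.13 log units; within the scatter)), although that single swap changes both the halogen and its ring position, so neither can be judged alone.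

From the compounds shown here alone, it remains open whether an amine or a carboxylic acid on the ring, or a longer chain in place of the ((3-chlorophenyl)carbamoyl)amino group, would bring the number below that of compound 3. Nothing available here explains why the longer group goes with the higher numbers.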